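A Benzyl Group in Place of Methyl: Compound 4 Expected

The source may hold more compounds than are shown below. What is called first, only, known or untested is meant among the compounds shown, and "the series" means these compounds.

compound 1 `Cn1cc(C(N)=O)c2c(N)ncnc21` — > 100000 nM
compound 2 `Cc1ccc(Cn2cc(C#N)c3c(N)ncnc32)cc1` — > 100000 nM
compound 3 `Cn1cc(C(=N)S)c2c(N)ncnc21` — 15000 nM

In a functional assay on KB cells (Homo sapiens) for cytotoxicity (on this read-out lower numbers stand for stronger inhibition and higher numbers for weaker inhibition), compound 1 `Cn1cc(C(N)=O)c2c(N)ncnc21` gives only a limit, > 100000 nM. Compound 2 `Cc1ccc(Cn2cc(C#N)c3c(N)ncnc32)cc1` also gives only a limit, > 100000 nM. Going by the values given here, compound 3 `Cn1cc(C(=N)S)c2c(N)ncnc21` gives a number, 15000 nM, and the single measured step, an at least 6.6-fold lower number from compound 1 to compound 3 (0.82 log units; beyond the scatter), concerns the group on the aromatic carbon. Compound 4 `NC(=O)c1cn(Cc2ccccc2)c2ncnc(N)c12` differs from compound 1 elsewhere: phenyl in place of hydrogen on a saturated chain carbon bound to an aromatic nitrogen. Among the compounds with values here, no measured step touches that chain, so the measured step does not bear on it. Compound 2 carries a larger group on the same chain, and two of the three values sit at the limit (the limit of > 100000 nM in this assay, at which 2 of the 3 values shown sit). Compound 4 is therefore expected to remain near that limit, an estimated 150000 nM (range 30000 nM to 800000 nM), a step that the limit leaves unreadable from compound 1 to compound 4.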

Compound 4, half-maximal inhibitory concentration: 75000 nM
For compound 4 the middle estimate is 2.0-fold (0.30 log units) above the measured one; the measured number falls inside the stated range.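

This chain had no reading before: in this assay phenyl in place of hydrogen on a saturated chain carbon bound to an aromatic nitrogen gives an at least 1.3-fold lower number from compound 1 to compound 4 (0.12 log units; that floor lies within the scatter) and so shows no change that clears the scatter, though a larger one is not excluded. The true size stays unfixed because compound 1 carries only a limit: the limit of > 100000 nM in this assay, at which 2 of the 4 values shown sit.

From the compounds shown here alone, whether an amine on the phenyl, or a longer chain carrying that ring, would shift the number stays open. Also open, going by these compounds, is whether the group on the aromatic carbon of compound 3 would combine with phenyl on this chain.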